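Triazole substituent swap: aryl for heptyl in compound 4

This account rests on a few compounds, and the source may have more. Where it says the series, first, only, none or still open, it means among the compounds named here.

In an ADME assay on PANC-1 cells (Homo sapiens) for cytotoxicity, read by sulforhodamine B assay, with a stated time of 48 h, tested at 10 uM (a higher number here means more inhibition at the concentration tested (going by the name of the read-out), a lower number less inhibition), compound 1 `COc1nc2ccc(Br)cc2cc1C(c1ccccc1)n1cc(-c2ccc(Br)cc2)nn1` gives 10.4%, compound 2 `CCCCCCCc1cn(C(c2ccccc2)c2cc3cc(Br)ccc3nc2OC)nn1` gives 16.6% and compound 3 `CCCCc1cn(C(c2ccccc2)c2cc3cc(Br)ccc3nc2OC)nn1` gives 5.46%. For the measured compounds named here, compound 2 holds the largest of the three numbers, but its gap to compound 1, a number 6.2 percentage points higher from compound 1 to compound 2 (within the scatter), is within the scatter; only the step of a number 11.1 percentage points lower from compound 2 to compound 3 (beyond the scatter) lies beyond it, and that one is modest.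

Compound 4 `COc1nc2ccc(Br)cc2cc1C(c1ccccc1)n1cc(-c2ccccc2F)nn1` arises from compound 2 by 2-fluorophenyl in place of heptyl on an aromatic carbon. Going by the values given here, the step that bears most directly on this change is the one from compound 1 to compound 2, where a number 6.2 percentage points higher from compound 1 to compound 2 (within the scatter); read in reverse, exchanging heptyl for an aryl group on that aromatic carbon moved the number by an amount inside the scatter. The step of a number 4.9 percentage points lower from compound 1 to compound 3 (within the scatter) shows that exchanging the same aryl group for a shorter chain also stayed inside the scatter. The shortening step a number 11.1 percentage points lower from compound 2 to compound 3 (beyond the scatter) does not apply here, since the entering group is aromatic rather than a chain.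

Compound 4 is therefore expected to sit close to compound 2, with a step of a number 5.6 percentage points lower from compound 2 to compound 4 (within the scatter) that should not exceed the scatter. The estimate for compound 4 in this assay is 11%, with a range from 3% to 20%.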

Compound 4, a percentage reported as inhibition, at one concentration (the size of the read-out at that concentration, not a potency): 14.7%
Compound 4: middle estimate off by 3.7 percentage points, on the low side; the range from low to high includes it.
By their numbers in this assay, from the lowest: compounds 3, 1, 4 and 2 (each within the scatter of the next, the first and the last beyond it).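

In this assay, the aromatic carbon of the five-membered aromatic ring with 3 nitrogen accepts an aryl group or a chain with no separation between them: the step of a number 1.9 percentage points lower from compound 2 to compound 4 (within the scatter) exchanges heptyl for 2-fluorophenyl, each with 7 heavy atoms, and stays inside the scatter. The two aryl groups cannot be told apart either, since the step of a number 4.3 percentage points higher from compound 1 to compound 4 (within the scatter) exchanges 4-bromophenyl for 2-fluorophenyl and also stays inside the scatter, so this pair gives no reading on the identity of the halogen or its place on the phenyl ring. The step of a number 9.2 percentage points higher from compound 3 to compound 4 (within the scatter) keeps compound 4 within the scatter of the butyl compound as well, which leaves the step of a number 11.1 percentage points lower from compound 2 to compound 3 (beyond the scatter) as the only one in the set that lies beyond the scatter, and it is a change of chain length, not an exchange of chain for aryl.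

The compounds shown leave open whether an amine, a carboxylic acid or a much longer chain at this carbon would move the number beyond the scatter. Nothing available here accounts for why these groups read alike.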